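A few compounds are considered here, and "the series" means these few. Any claim that something is new, unique, unknown or untested is made for them only; others in the source may bear on it.

Measured compounds in the series:

Compound 1, `Oc1ccc(CNc2ncnc3c2ncn3C2CCCCO2)cc1`. In an ADME assay on BJ cells (Homo sapiens) for cytotoxicity, read by MTT assay, with a stated time of 72 h (on this read-out higher numbers stand for weaker inhibition and lower numbers for stronger inhibition), compound 1 gives > 100000 nM, which is a limit of the assay and not a number.
Compound 2, `COc1ccc(CNc2ncnc3c2ncn3C2CCCCO2)cc1`. In this assay compound 2 gives > 100000 nM, again a limit of the assay.
Compound 3, `COc1cc(CNc2ncnc3c2ncn3C2CCCCO2)ccc1O`. In this assay compound 3 gives > 100000 nM, also a limit of the assay.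

Compound 2 differs from compound 1 by methyl in place of hydrogen on an oxygen on an aromatic ring. The step in this assay is a step that the two limits leave unreadable from compound 1 to compound 2. Compound 3 differs from compound 1 by methoxy in place of hydrogen on an aromatic carbon, and the step there is a step that the two limits leave unreadable from compound 1 to compound 3. Neither step can be sized, since both ends sit at the same limit; this is what the limit of > 100000 nM in this assay, at which 3 of the 3 values shown sit, shows.

Not yet measured is compound 4, `COc1ccc(CNc2ncnc3c2ncn3C2CCCCO2)c(OC)c1`, which differs from compound 2 by methoxy in place of hydrogen on an aromatic carbon. This is the same kind of change as that from compound 1 to compound 3, not the same change: there the entering methoxy sits ortho to a hydroxy group and meta to a large group, whereas in compound 4 it sits ortho to a large group and meta to a methoxy group.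

For compound 4 the expected step from compound 2 in this assay is a step that the limit leaves unreadable from compound 2 to compound 4, an expectation that rests on (the limit of > 100000 nM in this assay, at which 3 of the 3 values shown sit), where every measured member of the series sits. The estimate for compound 4 is therefore 150000 nM, with an expected range from 70000 nM to 400000 nM, and most likely the assay will again report only a limit.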

Compound 4, half-maximal inhibitory concentration: > 25000 nM
Compound 4 was reported as a limit; the forecaster's own chance of this, stated with the estimate: 85%; the middle value is on the limit's open side.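

In this assay compound 2 gives > 100000 nM, a limit of the assay and not a number. Among these compounds, compound 4 gives > 25000 nM, also a limit, so no step between compound 2 and compound 4 can be read. The compounds shown leave open whether methoxy in place of hydrogen on an aromatic carbon changes the value in this assay at all, as none gives a value beyond a limit.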